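The compounds below may be only part of what the source reports. "The series", "measured", "known", "first", "only" and "open" are said of these compounds alone.

Three compounds sharing one core have so far been run in a functional assay on UACC-257 cells (Homo sapiens) for inhibition, read by sulforhodamine B assay, with a stated time of 48 h, tested at 100 uM; on this read-out lower numbers stand for a stronger effect and higher numbers for a weaker effect at the one concentration tested. Compound 1 `COc1cc(Cl)cc(-c2nn(-c3cccc(NC(=O)Nc4ccc(Cl)c(C(F)(F)F)c4)c3)cc2-c2ccncc2)c1` gives -86% in this assay. Compound 2 `COc1cc(Cl)cc(-c2nn(-c3cccc(NC(=O)c4cccc(C(F)(F)F)c4)c3)cc2-c2ccncc2)c1` gives 52%, the highest of the three numbers: the nearest to it is compound 1, the step of a number 138 percentage points higher from compound 1 to compound 2 (beyond the scatter) lying beyond the scatter, and the furthest is compound 3 `O=C(Nc1cccc(-n2cc(-c3ccncc3)c(-c3cc(O)cc(Cl)c3)n2)c1)Nc1ccc(Cl)c(Cl)c1`, which gives -92%. Compound 4 `COc1cc(Cl)cc(-c2nn(-c3cccc(NC(=O)Nc4ccc(Cl)c(Cl)c4)c3)cc2-c2ccncc2)c1` has not yet been measured. Compared with compound 2 it carries one change: (3,4-dichlorophenyl)amino in place of 3-(trifluoromethyl)phenyl on a carbonyl carbon. Among the measured compounds shown here, the single measured step that bears on this is a number 138 percentage points higher from compound 1 to compound 2 (beyond the scatter), in which 3-(trifluoromethyl)phenyl took the place of (4-chloro-3-(trifluoromethyl)phenyl)amino on the carbonyl carbon and the number rose greatly. Compound 4 puts an arylamino group back on that carbonyl carbon, the same (3,4-dichlorophenyl)amino that compound 3 bears, and compound 3 gave -92%. The expected step is therefore large and downward, a number 137 percentage points lower from compound 2 to compound 4 (beyond the scatter). Compound 4 is expected to give about -85%, within a range from -100% to -55%.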

Compound 4, a percentage reported as activity, at one concentration (the size of the read-out at that concentration, not a potency): -36%
The estimate for compound 4 lay 49 percentage points below the measured number, and the stated range ends below it.
By their numbers in this assay, from the lowest: compounds 3 and 1 (each within the scatter of the next); then compound 4; then compound 2.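

In this assay, (3,4-dichlorophenyl)amino in place of 3-(trifluoromethyl)phenyl on the carbonyl carbon gives a number 88 percentage points lower from compound 2 to compound 4 (beyond the scatter), so an arylamino group at this position lowers the number here too, but the rest of the molecule still matters. Chloro in place of trifluoromethyl on an aromatic carbon gives a number 50 percentage points higher from compound 1 to compound 4 (beyond the scatter), and methyl in place of hydrogen on an oxygen on an aromatic ring gives a number 56 percentage points higher from compound 3 to compound 4 (beyond the scatter), so neither the arylamino group nor the change at the carbonyl carbon alone sets the number. Nothing available explains these steps.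

The compounds shown leave open whether the hydroxy group and the 4-chloro-3-(trifluoromethyl)phenyl group together would shift the number further. They also leave open whether a cyclohexylamino group on the carbonyl carbon would act as the arylamino groups do.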